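Removing the amide cap from a pyrazolopyrimidine ALK2 inhibitor

The source may hold more compounds than are shown below. What is called first, only, known or untested is meant among the compounds shown, and "the series" means these compounds.

Measured compounds:
- compound 1, `COCC(=O)N1C[C@@H](C)N(c2ncc3[nH]nc(-c4ccc(N5CCN[C@H](C)C5)nc4)c3n2)[C@@H](C)C1`: 7.3 nM
- compound 2, `CC(C)C(=O)N1C[C@@H](C)N(c2ncc3[nH]nc(-c4ccc(N5CCN[C@H](C)C5)nc4)c3n2)[C@@H](C)C1`: 8 nM

In an assay on Sf9 cells for inhibition of activin receptor type-1 (Homo sapiens), read by HTRF, with a stated time of 3 h, in the presence of a further agent that is not named here (a lower number here means a stronger inhibitor, a higher number a weaker inhibitor), compound 1 gives 7.3 nM, the lowest of the two numbers shown, and compound 2 gives 8 nM, so the two compounds cannot be told apart on this read-out. Among the measured compounds shown here, the only measured step, a 1.1-fold higher number from compound 1 to compound 2 (0.04 log units; within the scatter), swaps one group on the carbonyl carbon for another and leaves the number essentially where it was.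

Compound 3, `C[C@@H]1CN(c2ccc(-c3n[nH]c4cnc(N5[C@H](C)CNC[C@@H]5C)nc34)cn2)CCN1`, goes further: the carbonyl group is taken away altogether, (hydrogen in place of (methoxymethyl)carbonyl on an amine nitrogen in a ring), so the ring nitrogen that carried it now carries only a hydrogen. The step from compound 1 to compound 2 bears on this only loosely: it shows that the identity of the group on the carbonyl carbon does not matter much, but it says nothing about losing the carbonyl itself. For the measured compounds named here, no measured pair shows that kind of change. The expected step is therefore small, possibly a modest rise in the number, with wide uncertainty: the estimate for compound 3 is 15 nM, between 4 nM and 60 nM, a step of a 2.1-fold higher number from compound 1 to compound 3 (0.31 log units; beyond the scatter).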

Compound 3, half-maximal inhibitory concentration: 793 nM
Beside the measured number, compound 3's estimate is 53-fold (1.72 log units) below it; measured number above the stated range.
By their numbers in this assay, from the lowest: compounds 1 and 2 (each within the scatter of the next); then compound 3.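

In this assay, the group on this amine nitrogen matters far more than the earlier pair could show: replacing it with hydrogen gives a 110-fold higher number from compound 1 to compound 3 (2.04 log units; beyond the scatter), and the same change from the other amide gives a 99-fold higher number from compound 2 to compound 3 (2.00 log units; beyond the scatter). Taken with the first pair, this means that the number stays put when (methoxymethyl)carbonyl is exchanged for isopropylcarbonyl, but not when the whole cap leaves the ring nitrogen and only a hydrogen remains. Nothing available here explains why the number climbs so steeply with this change.

The step removes the carbonyl and everything attached to it at once while leaving a hydrogen on the ring nitrogen, so the compounds shown cannot separate the contributions of those three changes. A plain ethyl group on that nitrogen would keep a short carbon chain without the carbonyl, and a formyl group would keep the carbonyl with only a hydrogen on its carbon, so how each would read in this assay remains an open question.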